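Esterifying the Phenol: From Compound 1 to Compound 3

The source may report more compounds than this note shows. Statements on the series, on what has been measured and on what is new or still open speak of the compounds shown alone.

For the measured compounds named here, compound 1 `COc1ccc(/C=C/C(=O)c2ccc(OC)c3c2OC(C)(C)C=C3)cc1O` stands at the higher of the two numbers measured so far: in a functional assay on A-375 cells (Homo sapiens) for cytotoxicity, read by MTT assay (a higher number here means a weaker inhibitor, a lower number a stronger inhibitor), compound 1 gives 800 nM. Its nearest neighbour is compound 2 `COc1ccc(/C=C/C(=O)c2ccc(OC)c3c2OC(C)(C)C=C3)cc1OC(=O)C1CC1`, which in this assay gives 380 nM. The two differ only by a cyclopropylcarbonyl in place of hydrogen on an oxygen on an aromatic ring, and that single change produced a 2.1-fold lower number from compound 1 to compound 2 (0.32 log units; beyond the scatter).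

Compound 3 `COc1ccc(/C=C/C(=O)c2ccc(OC)c3c2OC(C)(C)C=C3)cc1OC(=O)c1ccc(Br)cc1` changes compound 1 at the same oxygen, with a larger group: (4-bromophenyl)carbonyl in place of hydrogen on an oxygen on an aromatic ring. Going by the values given here, the only measured step that bears on this is the one from compound 1 to compound 2, where placing an acyl group on this oxygen lowered the number beyond the scatter by a modest amount. A similar modest lowering is therefore expected for compound 3, corresponding to a 2.0-fold lower number from compound 1 to compound 3 (0.30 log units; within the scatter). Compound 3 is estimated at 400 nM, with a range from 150 nM to 1000 nM.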

Compound 3, half-maximal inhibitory concentration: 420 nM
Compound 3: the middle estimate sits 1.1-fold (0.02 log units) below what was measured; low and high end bracket the measured number.
By their numbers in this assay, from the lowest: compounds 2, 3 and 1 (each within the scatter of the next, the first and the last beyond it).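

In this assay, replacing cyclopropyl with 4-bromophenyl on the carbonyl carbon gives a 1.1-fold higher number from compound 2 to compound 3 (0.04 log units; within the scatter), so the two esters cannot be told apart, even though the acyl groups they carry are very different in shape and size. The picture at this oxygen is less clear-cut than the first ester suggested: the change to (4-bromophenyl)carbonyl gives a 1.9-fold lower number from compound 1 to compound 3 (0.28 log units; within the scatter), so this ester cannot be separated from the free phenol, whereas compound 2 can. Compound 2 and compound 3 thus sit within the scatter of each other, while only compound 2 lies beyond it from compound 1. Nothing available here explains why the two esters read alike.

On these data alone, it remains open how an acyl group carrying an amine or a carboxylic acid would read at this oxygen. As far as these compounds go, whether a methyl ether or a longer alkyl chain on the same oxygen would match the esters also remains open.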